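From compound 2 to compound 3: one group exchanged

This account rests on a few compounds, and the source may have more. Where it says the series, first, only, none or still open, it means among the compounds named here.

Compound 1 `O=C(Nc1cc(-c2ccccn2)n[nH]1)N1CCC(Oc2ccccc2)CC1`: > 64000 nM
Compound 2 `O=C(Nc1cc(-c2ccccn2)n[nH]1)N1CCC(c2ccc(Cl)cc2)CC1`: > 62000 nM
Compound 3 `O=C(Nc1cc(-c2ccccn2)n[nH]1)N1CCC(Oc2ccccn2)CC1`: not yet measured

In an ADME assay on MRC5 cells (Homo sapiens) for cytotoxicity, read by fluorescence and resazurin assay, with a stated time of 3 days (a lower number here means that less compound is tolerated, a higher number that more compound is tolerated), compound 2 gives > 62000 nM, which is a limit and not a number. Compound 1 gives > 64000 nM, which is also a limit. So neither measured compound has a number in this assay.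

Compound 3 departs from compound 2 by one exchange: (pyridin-2-yl)oxy in place of 4-chlorophenyl on a saturated ring carbon.

Among the measured compounds shown here, only one measured step bears on this change: a step that the two limits leave unreadable from compound 1 to compound 2. Its size cannot be read, so it offers no measured effect to carry over. With compound 2 standing at the limit of > 62000 nM, no step beyond the usual scatter is expected in this assay.

The expected step is a step that the limit leaves unreadable from compound 2 to compound 3. Compound 3 is estimated at 64000 nM, with an expected range from 30000 nM to 100000 nM. A limit rather than a number is the likely report.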

Compound 3, half-maximal cytotoxic concentration: > 63000 nM
Compound 3: no number, only a limit; the forecaster's own chance of this, stated with the estimate: 85%; the middle value is on the limit's open side.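

In this assay compound 3 gives > 63000 nM as a limit and not a number, so the steps to it from compound 1 and from compound 2 cannot be read. The compounds shown leave open the concentration at which any of the three would reach half-maximal cytotoxicity.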